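This account rests on a few compounds, and the source may have more. Where it says the series, first, only, none or still open, it means among the compounds named here.

Compound 2 `C[C@H](NC(=O)Nc1ccccc1C(C)(C)C)c1ccccc1` and compound 1 `C[C@@H](NC(=O)Nc1ccccc1C(C)(C)C)c1ccccc1` share every atom and bond and differ only in the configuration as drawn at the saturated chain carbon. In an ADME assay on the whole organism with Oryza sativa as the target, tested at 0.1 uM (on this read-out higher numbers stand for a weaker effect at the one concentration tested and lower numbers for a stronger effect), compound 1 gives 100%, and compound 2 gives 101%. For the measured compounds named here, the step of a number 1 percentage points higher from compound 1 to compound 2 (within the scatter) is the only single-point comparison so far and rests on (the fact that compounds 1 and 2 differ only in the configuration as drawn). Going by the values given here, compound 3 `CCCCCCc1ccc(NC(=O)N[C@@H](C)c2ccccc2)cc1` differs from compound 2 in more than one place, and in this assay compound 3 gives 99%; for that pair no step is given, and the two numbers show no gap beyond the scatter. Compound 2 therefore stands level with both neighbours: its value lies within the scatter of compound 1 and of compound 3, and no ordering of the three can be drawn.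

Compound 4 `CC(=O)c1ccccc1NC(=O)N[C@@H](C)c1ccccc1` is the next entry: acetyl in place of tert-butyl on an aromatic carbon. Among the compounds with values here, no measured step covers a substituent change of this kind; the single measured step concerns configuration alone and was within the scatter, and all three values so far sit together. The data give no ground for a move in either direction in this assay. For compound 4 the expected read-out is estimated at 100%, with a range of 88% to 110%. From compound 2 this estimate means a step of a number 1 percentage points lower from compound 2 to compound 4 (within the scatter), expected to stay within the scatter.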

Compound 4, a percentage reported as activity, at one concentration (the size of the read-out at that concentration, not a potency): 100%
Beside the measured number, compound 4's estimate shows no gap at the digits printed; the range from low to high includes it.
By their numbers in this assay, from the lowest: compounds 3, 1, 4 and 2 (each within the scatter of the next).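

In this assay, acetyl in place of tert-butyl on an aromatic carbon, ortho to a large group, gives a number 1 percentage points lower from compound 2 to compound 4 (within the scatter). For the compounds shown here, this is the first step that changes a substituent rather than configuration alone, and it shows that this position can take a group with a different atom count and composition without a step beyond the scatter: acetyl brings an oxygen, a double bond outside aromatic rings and a hydrogen-bond acceptor, none of which tert-butyl has. Nothing measured on these compounds bears on why this step stays so small.

Going by these compounds alone, whether an amine, a carboxylic acid or a longer chain on this aromatic carbon would stay within the scatter of compound 2 remains open, since tert-butyl and acetyl are the only two groups compared here in a single-point step. All four compounds sit within the scatter of one another in this assay, so the compounds shown do not yet include any structural change that separates one number from the rest.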